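This account rests on a few compounds, and the source may have more. Where it says the series, first, only, none or still open, it means among the compounds named here.

Measured so far in an assay on cells for agonist activity at ecdysone receptor (Bombyx mori), read by a luciferase reporter, with a stated time of 24 h; on this read-out lower numbers stand for an effect already at smaller amounts and higher numbers for an effect only at larger amounts of compound:
compound 1 `CC(C)(C)N(NC(=O)c1ccccc1)C(=O)c1ccccc1Cl` — 75.9 nM
compound 2 `CC(C)(C)N(NC(=O)c1ccccc1)C(=O)c1ccccc1C(F)(F)F` — 631 nM
compound 3 `CC(C)(C)N(NC(=O)c1ccccc1Cl)C(=O)c1ccccc1Cl` — 331 nM

Compound 3 gives the second highest of the three numbers in this assay. Its nearest neighbour is compound 2, whose value lies within the scatter of that of compound 3; compound 1 lies further off, with a clearly lower number. The step of a 4.4-fold higher number from compound 1 to compound 3 (0.64 log units; beyond the scatter) came with a chloro in place of hydrogen on an aromatic carbon, and the step of an 8.3-fold higher number from compound 1 to compound 2 (0.92 log units; beyond the scatter) with a trifluoromethyl in place of chloro on an aromatic carbon of the other ring.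

Compound 4 `CC(C)(C)N(NC(=O)c1ccccc1I)C(=O)c1ccccc1Cl` is not yet measured. It differs from compound 3 by iodo in place of chloro on an aromatic carbon. No measured step swaps one halogen for another at this place; the two steps shown bear on it only indirectly, in that both changes at a ring substituent moved the number upward by a modest amount. An iodo for chloro exchange is a smaller structural change than either of those, so a step in this assay of no more than modest size is expected, most likely toward a higher number, but one within the scatter cannot be excluded. The estimated step is a 1.4-fold higher number from compound 3 to compound 4 (0.13 log units; within the scatter). Compound 4 is therefore expected to give about 450 nM, with a range from 130 nM to 1600 nM.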

Compound 4, half-maximal effective concentration: 1290 nM
Estimate against measurement, compound 4: 2.9-fold (0.46 log units) below; the measured number falls inside the stated range.
By their numbers in this assay, from the lowest: compound 1; then compounds 3 and 2 (each within the scatter of the next); then compound 4.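

Working from the 2-chlorophenyl group of compound 3, iodo in place of chloro gave a 3.9-fold higher number from compound 3 to compound 4 (0.59 log units; beyond the scatter) in this assay, so the identity of the halogen at this place matters, which the earlier compounds could not show. Among the compounds shown here, measured against the unsubstituted ring of compound 1, the same place gives a 17-fold higher number from compound 1 to compound 4 (1.23 log units; beyond the scatter) with iodo, and the earlier chloro step, a 4.4-fold higher number from compound 1 to compound 3 (0.64 log units; beyond the scatter) at this place, is smaller; hydrogen, chloro and iodo therefore rank in that order from lower to higher numbers across compound 1, compound 3 and compound 4, with no compound in this three-member set going against the order. No measurement available here speaks to what lies behind these rises.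

As far as these compounds go, whether the order extends to fluoro or bromo at this place, and how a methyl, a methoxy, an amine or a carboxylic acid would sit in it, remains open. Also open, from the compounds shown here alone, is whether iodo in place of chloro on the other ring, where compound 1 carries its chloro, would give a step of similar size.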